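The source may hold more compounds than are shown below. What is called first, only, known or untested is meant among the compounds shown, and "the series" means these compounds.

In a functional assay (aorta) with Rattus norvegicus as the target (on this read-out lower numbers stand for an effect already at smaller amounts and higher numbers for an effect only at larger amounts of compound), compound 1 `COc1ccc(-c2nc(C(=O)N=C(N)N)sc2-c2ccc(OC)cc2)cc1` returns > 100 uM as a limit and not a number. Among the compounds with values here, compound 2 `COc1ccc(-c2nc(C(=O)N3CCCCC3)sc2-c2ccc(OC)cc2)cc1` gives 11 uM as the only actual number so far. Compound 3 `COc1ccc(-c2nc(C(=O)N3CCCCC3CCO)sc2-c2ccc(OC)cc2)cc1` carries 2-hydroxyethyl in place of hydrogen on a saturated ring carbon of compound 2 (2-hydroxyethyl in place of hydrogen on a saturated ring carbon) next to the ring nitrogen. Within the data shown here, the one measured step (an at least 9.0-fold lower number from compound 1 to compound 2 (0.95 log units; beyond the scatter)) exchanged the whole group on the carbonyl carbon and so bears only loosely on this change. No step beyond the scatter is therefore expected in this assay and the estimated step is a 1.1-fold higher number from compound 2 to compound 3 (0.04 log units; within the scatter) in size. Compound 3 is expected at 12 uM within a range of 3 uM to 50 uM on this read-out.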

Compound 3, concentration for half-maximal effect: 6.8 uM
Beside the measured number, compound 3's estimate is 1.8-fold (0.25 log units) above it; low and high end bracket the measured number.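

In this assay this position, a saturated ring carbon next to the ring nitrogen, accepts 2-hydroxyethyl without a change beyond the scatter (a 1.6-fold lower number from compound 2 to compound 3 (0.21 log units; within the scatter)). The larger group on the carbonyl carbon also keeps the gain over the group of compound 1 (an at least 14-fold lower number from compound 1 to compound 3 (1.16 log units; beyond the scatter)). The size of that gain remains a bound, since the value of compound 1 is a limit and not a number: the limit of > 100 uM in this assay, at which 1 of the 3 values shown sits.

From the compounds shown here alone, whether the terminal hydroxyl contributes anything stays open, as ethyl, 3-hydroxypropyl or 2-aminoethyl at this carbon would separate the chain from its end group. Going by these compounds, the other ring carbons also remain open.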